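Trimming a butyl chain to methyl on a cytotoxic core

This account rests on a few compounds, and the source may have more. Where it says the series, first, only, none or still open, it means among the compounds named here.

Of the compounds shown here, two have been measured in a functional assay on NCI-H460 cells (Homo sapiens) for cytotoxicity, read by MTT assay, with a stated time of 72 h; on this read-out lower numbers stand for stronger inhibition and higher numbers for weaker inhibition. Compound 1 `CCCCNC1=CC(=O)C=C(C(C)(C)C)C1=O` gives 14000 nM in this assay, the lowest of the two numbers. Compound 2 `CC1=CCC[C@H]2[C@](C)(CC3=CC(=O)C=CC3=O)[C@@H](C)CC[C@]12C`, a different scaffold, gives 84000 nM in this assay, a weaker result that lies beyond the scatter; since the two compounds share no single point of difference, only their two values can be compared.

Compound 3 `CNC1=CC(=O)C=C(C(C)(C)C)C1=O` keeps the core of compound 1 and differs at the amine side chain: hydrogen in place of propyl on a saturated chain carbon bound to an amine nitrogen. Among the compounds with values here, no measured pair shows what removing three chain carbons does here. Within the data shown here, a modest weakening is expected, since the core itself remains intact and the chain is the only change. Compound 3 is therefore estimated at 25000 nM, within 8000 nM to 80000 nM, a step of a 1.8-fold higher number from compound 1 to compound 3 (0.25 log units; within the scatter) that is expected to stay close to the usual scatter.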

Compound 3, half-maximal inhibitory concentration: 25000 nM
Compound 3: middle estimate and measured number agree at the digits printed; the measured number falls inside the stated range.
By their numbers in this assay, from the lowest: compounds 1 and 3 (each within the scatter of the next); then compound 2.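

Within the data shown here, this is the first pair that differs in only one place, so it gives the first direct reading of the amine side chain. Cutting butyl back to methyl on the amine nitrogen gives a 1.8-fold higher number from compound 1 to compound 3 (0.25 log units; within the scatter) in this assay so the two compounds cannot be told apart, and at this position the three outer chain carbons can go without a change that stands clear of the scatter. Nothing measured here offers an explanation for this result.

Butyl and methyl are both plain saturated chains, so this step says little about a different kind of group at this position. As far as these compounds go, a longer chain such as octyl, or a chain ending in a carboxylic acid or an amine, might still shift the number, and that remains open.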